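The source may report more compounds than this note shows. Statements on the series, on what has been measured and on what is new or still open speak of the compounds shown alone.

Measured so far in a functional assay on CCRF-CEM cells (Homo sapiens) for cytotoxicity, read by cell counting, with a stated time of 3 days; on this read-out higher numbers stand for weaker inhibition and lower numbers for stronger inhibition:

compound 1 `C=C(Br)C(=O)Nc1cccc(/C=C2\SC(=O)N(Cc3ccc(C(F)(F)F)cc3)C2=O)c1` gives 920 nM
compound 2 `C=C(Br)C(=O)Nc1cccc(/C=C2\SC(=O)N(Cc3ccc(Cl)cc3)C2=O)c1` gives 1400 nM
compound 3 `C=C(Br)C(=O)Nc1cccc(/C=C2\SC(=O)N(Cc3cccc(Cl)c3)C2=O)c1` gives 1400 nM

Compound 3 sits level with compound 2 at the digits shown, and the two together hold the highest numbers of the three; the step of a 1.5-fold higher number from compound 1 to compound 3 (0.18 log units; within the scatter) is within the scatter, so no order among the three can be read from these values.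

Compound 4 `C=C(Br)C(=O)Nc1cccc(/C=C2\SC(=O)N(Cc3ccccc3)C2=O)c1` is not yet measured. It differs from compound 3 by hydrogen in place of chloro on an aromatic carbon.

Among the compounds with values here, two measured steps bear on this change, both touching the same benzyl substituent. The step of a 1.5-fold higher number from compound 1 to compound 2 (0.18 log units; within the scatter) swaps one group for another on the aromatic carbon and stays within the scatter. The step of no change at the digits printed from compound 2 to compound 3 (within the scatter) moves the chloro to a different aromatic carbon and gives no change at the digits shown. Neither step removes the substituent outright, so the step to compound 4 is not directly tested; what is tested is that the read-out has so far been insensitive to what sits on that ring and where. The expectation for the step of a 1.1-fold higher number from compound 3 to compound 4 (0.06 log units; within the scatter) is therefore none beyond the scatter, leaning if anything toward a slightly higher number.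

Compound 4 is estimated at 1600 nM, with a range of 700 nM to 3600 nM.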

Compound 4, half-maximal inhibitory concentration: 510 nM
Beside the measured number, compound 4's estimate is 3.1-fold (0.50 log units) above it; measured number outside the range, below it.
By their numbers in this assay, from the lowest: compounds 4, 1, 2 and 3 (each within the scatter of the next, the first and the last beyond it).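

In this assay the unsubstituted benzyl group of compound 4 separates from both chlorinated compounds: hydrogen in place of chloro gives a 2.7-fold lower number from compound 3 to compound 4 (0.44 log units; beyond the scatter) on going from 3-chlorobenzyl to benzyl, and a 2.7-fold lower number from compound 2 to compound 4 (0.44 log units; beyond the scatter) from the 4-chlorophenyl counterpart, both modest but beyond the scatter. Hydrogen in place of trifluoromethyl gives a 1.8-fold lower number from compound 1 to compound 4 (0.26 log units; within the scatter) and stays within the scatter, so compound 1 goes against any general rule that a substituent on this ring raises the number. The ring therefore no longer looks indifferent: swapping or moving a substituent had shown nothing, whereas removing chloro registers, and this holds only for the two chloro compounds.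

Still open, as far as these compounds go, is where other groups on this ring would fall, for instance an amine, a carboxylic acid or a methoxy group, and whether a longer chain in place of benzyl keeps the number of compound 4. The bromoacrylamide part and the shared core stay constant across these compounds, so their contribution remains unknown, and nothing available accounts for the gap seen with chloro.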